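Replacing dimethylamino by imidazolyl: what to expect

This account rests on a few compounds, and the source may have more. Where it says the series, first, only, none or still open, it means among the compounds named here.

Compound 1, `COc1ccc(/C=C/C(=O)c2ccc(OC)c3c2OC(C)(C)C=C3)c(F)c1`: in a functional assay on HT-29 cells (Homo sapiens) for antiproliferative activity, read by MTT assay, with a stated time of 24 h (on this read-out higher numbers stand for weaker inhibition and lower numbers for stronger inhibition), compound 1 gives > 10000 nM, a limit of the assay.
Compound 2, `COc1ccc(C(=O)/C=C/c2cccc(F)c2)c2c1C=CC(C)(C)O2`: in this assay compound 2 gives > 10000 nM, a limit of the assay.
Compound 3, `COc1ccc(C(=O)/C=C/c2ccc(N(C)C)cc2)c2c1C=CC(C)(C)O2`: in this assay compound 3 gives 1870 nM.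

Compound 3 is the only one of the three with a number; the other two stop at the limit of > 10000 nM in this assay, at which 2 of the 3 values shown sit. The two measured steps that reach a number are an at least 5.3-fold lower number from compound 1 to compound 3 (0.72 log units; beyond the scatter) and an at least 5.3-fold lower number from compound 2 to compound 3 (0.72 log units; beyond the scatter), both of which put the 4-(dimethylamino)phenyl group in place of a fluorine-bearing phenyl. The step that the two limits leave unreadable from compound 1 to compound 2 cannot be read.

Compound 4, `COc1ccc(C(=O)/C=C/c2ccc(-n3ccnc3)cc2)c2c1C=CC(C)(C)O2`, differs from compound 3 by 1H-imidazol-1-yl in place of dimethylamino on an aromatic carbon. Going by the values given here, no measured step changes this group, so the two informative steps speak only indirectly: they show that compound 3 owes its number to the dimethylamino-bearing ring, and the new group is not that ring. The expectation is therefore a weaker or similar result, with a real chance of a limit. Compound 4 is estimated at 4500 nM, within 1500 nM to 20000 nM, meaning an expected step of a 2.4-fold higher number from compound 3 to compound 4 (0.38 log units; beyond the scatter).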

Compound 4, half-maximal inhibitory concentration: > 6600 nM
Compound 4 gave a limit, no number; the forecaster's own chance of this, stated with the estimate: 40%; at least 1.4-fold (0.16 log units) between middle value and limit.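

Swapping dimethylamino for 1H-imidazol-1-yl, with the rest of compound 3 unchanged, gives in this assay an at least 3.5-fold higher number from compound 3 to compound 4 (0.54 log units; beyond the scatter). The earlier steps shown here replaced the whole substituted phenyl ring, whereas this one changes only the group on the aromatic carbon para to a large group, so it shows that the number of compound 3 depends on that group and that a nitrogen attached at this carbon is not enough to keep it. Compound 4 has a limit of the assay, not a number, so the step has a known minimum but no known full size: the limit of > 6600 nM in this assay, at which 1 of the 4 values shown sits.

The compounds shown leave open whether the activity of compound 3 survives a smaller change at this position, such as a plain amino group, diethylamino or a pyrrolidin-1-yl ring. They also cannot separate the features that change together in this swap, namely the added aromatic ring, the extra heavy atoms and the extra hydrogen-bond acceptor, and a saturated ring such as piperidin-1-yl would be one way to pull these apart.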